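The source may hold more compounds than are shown below. What is called first, only, known or untested is meant among the compounds shown, and "the series" means these compounds.

In an in vitro ADME assay on microsomes from liver (Homo sapiens) for metabolic stability (on this read-out higher numbers stand for fast clearance and lower numbers for slow clearance), compound 2 `O=C(O)c1ccnc(NC(=O)[C@H](CC2CCCC2)n2cnc(C(F)(F)F)c2)c1` gives < 8 mL/min/kg as a limit of the assay and not a number. Compound 1 `Cc1ccc(NC(=O)[C@H](CC2CCCC2)n2cnc(C(F)(F)F)c2)nc1` gives > 120 mL/min/kg and this too is a limit. Compound 3 `O=C(O)c1cnc(NC(=O)[C@H](CC2CCCC2)n2cnc(C(F)(F)F)c2)cn1` brings one change 5-carboxypyrazin-2-yl in place of 4-carboxypyridin-2-yl on an amide-type nitrogen with 5-carboxypyrazin-2-yl in place of 4-carboxypyridin-2-yl on an amide-type nitrogen. Going by the values given here, the only measured step that bears on this is an at least 15-fold lower number from compound 1 to compound 2 (1.17 log units; beyond the scatter) with 4-carboxypyridin-2-yl in place of 5-methylpyridin-2-yl, and compound 3 keeps the carboxy group gained there. No large move is therefore expected, and the estimated a number no lower from compound 2 to compound 3 (the limit leaves the size open) should stay within the scatter. For compound 3 the estimate is 8 mL/min/kg with an expected range from 5 mL/min/kg to 16 mL/min/kg on this read-out.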

Compound 3, clearance: < 8 mL/min/kg
Compound 3 gave a limit, no number; the forecaster's own chance of this, stated with the estimate: 60%; the middle value sits exactly at the limit.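

In this assay, compound 3 gives < 8 mL/min/kg, which is a limit of the assay and not a number. The 5-carboxypyrazin-2-yl group in place of 5-methylpyridin-2-yl on the amide-type nitrogen gives an at least 15-fold lower number from compound 1 to compound 3 (1.17 log units; beyond the scatter), so the large step seen with 4-carboxypyridin-2-yl also appears with a ring holding 2 hetero atoms. The step between compound 2 and compound 3 cannot be read because both values are limits: the limit of < 8 mL/min/kg in this assay, at which 2 of the 3 values shown sit.

Going by these compounds, whether a low number needs the carboxylic acid stays open. A primary amide or a nitrile on the same ring would test this.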